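The source may report more compounds than this note shows. Statements on the series, on what has been measured and on what is new or still open speak of the compounds shown alone.

Measured so far: compound 1 `Fc1ccc(-c2csc(N/N=C/c3ccccc3)n2)cc1` gives 40% in an in vitro assay on BTI-TN-5B1-4 cells for inhibition of Amine oxidase [flavin-containing] A (Homo sapiens), read by fluorescence, with a stated time of 15 min, tested at 100 uM; a higher number here means more inhibition at the concentration tested (going by the name of the read-out), a lower number less inhibition. Compound 2 `Clc1ccc(-c2csc(N/N=C/c3ccccc3)n2)cc1` gives 40% in this assay. Compound 3 `Cc1ccc(/C=N/Nc2nc(-c3ccc(F)cc3)cs2)cc1` is reported as "not active" (no number reported) in this assay, with no number attached.

The step of no change at the digits printed from compound 1 to compound 2 (within the scatter) accompanies the change (chloro in place of fluoro on an aromatic carbon). The core of compound 3 differs from that of compound 1 by methyl in place of hydrogen on an aromatic carbon. Among the compounds with values here, compound 4 `Cc1ccc(/C=N/Nc2nc(-c3ccc(Cl)cc3)cs2)cc1` has not been measured; it differs from compound 3 by chloro in place of fluoro on an aromatic carbon, which is the same change, at the same place, as the one from compound 1 to compound 2. That same change gave no change at the digits printed from compound 1 to compound 2 (within the scatter). A small step from compound 3 to compound 4 is therefore expected as well. Compound 3 has no number to start from, so only a low value can be anticipated. Compound 4 is therefore expected to give about 15%, estimated to lie between 0% and 35%.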

Compound 4, a percentage reported as inhibition, at one concentration (the size of the read-out at that concentration, not a potency): "not active" (no number reported)
Compound 4 has no reported number here; there is nothing to compare the estimate with.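

In this assay, within the data shown here, compound 3 and compound 4 both lack a number, so no step between them can be read. As far as these compounds go, what the 4-fluorophenyl to 4-chlorophenyl change does when the methyl group is present stays open, and nothing available bears on this result.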